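Tetrazole isomer swap on the side chain

The source may hold more compounds than are shown below. What is called first, only, known or untested is meant among the compounds shown, and "the series" means these compounds.

Values in a functional assay on HUVEC cells (Homo sapiens), read by scintillation counting and thymidine incorporation, with a stated time of 24 h; a lower number here means a stronger inhibitor, a higher number a weaker inhibitor:
- compound 1 `CCC(C)n1ncn(-c2ccc(N3CCN(c4ccc(OC[C@@H]5CO[C@@](Cc6ccccc6)(c6ccc(Cl)cc6Cl)O5)cc4)CC3)cc2)c1=O`: 513 nM
- compound 2 `CCC(C)n1ncn(-c2ccc(N3CCN(c4ccc(OC[C@@H]5CO[C@@](Cn6cnnn6)(c6ccc(Cl)cc6Cl)O5)cc4)CC3)cc2)c1=O`: 73 nM

Compound 2, at 73 nM, holds the lower of the two numbers in this assay. Next to be tested is compound 3 `CCC(C)n1ncn(-c2ccc(N3CCN(c4ccc(OC[C@@H]5CO[C@@](Cn6ncnn6)(c6ccc(Cl)cc6Cl)O5)cc4)CC3)cc2)c1=O`, which has the same atoms as compound 2, joined differently: 2H-tetrazol-2-yl in place of 1H-tetrazol-1-yl on a saturated chain carbon bound to a saturated ring carbon. In words, this places 2H-tetrazol-2-yl in place of 1H-tetrazol-1-yl on a saturated chain carbon bound to a saturated ring carbon.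

Within the data shown here, only one measured step bears on this, and only indirectly: a 7.0-fold lower number from compound 1 to compound 2 (0.85 log units; beyond the scatter). Among the measured compounds shown here, that modest step replaced phenyl with 1H-tetrazol-1-yl, and no pair yet compares the two tetrazolyl attachments. As far as these compounds go, the new tetrazole keeps the ring type and counts, so no step beyond the scatter is expected, and the direction stays open. The estimated shift is a 1.2-fold higher number from compound 2 to compound 3 (0.09 log units; within the scatter). The expected value for compound 3 is 90 nM, with an estimated range of 35 nM to 230 nM.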

Compound 3, half-maximal inhibitory concentration: 124 nM
The estimate for compound 3 lay 1.4-fold (0.14 log units) below the measured number; the measured number falls inside the stated range.
By their numbers in this assay, from the lowest: compounds 2 and 3 (each within the scatter of the next); then compound 1.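

In this assay, the step of a 1.7-fold higher number from compound 2 to compound 3 (0.23 log units; within the scatter) lies within the scatter, so this pair does not separate 1H-tetrazol-1-yl from 2H-tetrazol-2-yl on a saturated chain carbon bound to a saturated ring carbon. The step of a 4.1-fold lower number from compound 1 to compound 3 (0.62 log units; beyond the scatter) lies beyond the scatter, as does a 7.0-fold lower number from compound 1 to compound 2 (0.85 log units; beyond the scatter), so the lower number relative to the phenyl of compound 1 no longer rests on one tetrazole attachment alone. The data shown offer no explanation for these steps.

Still open, as far as these compounds go, is whether the lower number needs a tetrazole at all, or whether imidazol-1-yl or a carboxylic acid at this place would give a similar value. Also open, from the compounds shown here alone, is how a longer chain between the tetrazole and the saturated ring carbon would read in this assay.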